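A few compounds are considered here, and "the series" means these few. Any claim that something is new, unique, unknown or untested is made for them only; others in the source may bear on it.

Measured so far in a functional assay on MCF7 cells (Homo sapiens) for cytotoxicity, read by ELISA, with a stated time of 4 days (on this read-out lower numbers stand for stronger inhibition and higher numbers for weaker inhibition), as follows:
- compound 1 `Clc1ccc(-c2cc(-c3ccco3)nc(-c3ccc(Cl)s3)c2)o1` at 16900 nM
- compound 2 `Cc1ccc(-c2cc(-c3ccc(Cl)o3)cc(-c3ccc(Cl)s3)n2)cc1` at 3040 nM

Compound 2 has the lower of the two numbers, and the gap to compound 1 lies beyond the scatter. The next compound is compound 3 `Clc1ccc(-c2cc(-c3ccc(Cl)o3)cc(-c3ccc(Cl)s3)n2)cc1` with chloro in place of methyl on an aromatic carbon, para to a large group, so that 4-methylphenyl becomes 4-chlorophenyl: chloro in place of methyl on an aromatic carbon is the counted difference.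

Going by the values given here, only one measured step is available, and it bears on this change only indirectly. That step, a 5.6-fold lower number from compound 1 to compound 2 (0.75 log units; beyond the scatter), is modest and comes from 4-methylphenyl in place of furan-2-yl. Among the compounds with values here, no measured pair varies the group on the six-membered ring, so the data give no direction for this swap. A step beyond the scatter is therefore not expected in this assay for this exchange of one heavy atom. The expected step is a 1.2-fold lower number from compound 2 to compound 3 (0.08 log units; within the scatter) and would stay within the scatter. Compound 3 is estimated at 2500 nM with an expected range from 1000 nM to 6000 nM as the working figures.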

Compound 3, half-maximal inhibitory concentration: 12600 nM
Beside the measured number, compound 3's estimate is 5.0-fold (0.70 log units) below it; the measured number lies above the stated range.
By their numbers in this assay, from the lowest: compound 2; then compounds 3 and 1 (each within the scatter of the next).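

In this assay this position, on a six-membered aromatic ring of carbon only and para to a large group, proves sensitive to an exchange of one heavy atom: chloro in place of methyl gives a 4.1-fold higher number from compound 2 to compound 3 (0.62 log units; beyond the scatter) and leaves compound 2 with the lowest number of the three, beyond the scatter from both others. The earlier gain from 4-methylphenyl in place of furan-2-yl does not carry over to the chlorinated group, since 4-chlorophenyl in place of furan-2-yl gives only a 1.3-fold lower number from compound 1 to compound 3 (0.13 log units; within the scatter) in this series, so that gain depends on what the ring carries and not on the ring alone. No measurement at hand explains why methyl and chloro part here.

Going by these compounds alone, open is whether methyl is special at this position or only one of several groups that fit there, which a hydrogen, an ethyl, a methoxy or an amine in the same place would help to settle. Also open, on these data alone, is whether the gap between methyl and chloro persists when the furan-2-yl and chlorinated groups elsewhere on the shared core change.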